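A longer amino chain on compound 2

The source may report more compounds than this note shows. Statements on the series, on what has been measured and on what is new or still open speak of the compounds shown alone.

Values so far in a functional assay on the whole organism for inhibition, with Mus musculus as the target; a higher number here means that more compound is needed for the effect, a lower number that less compound is needed:
- compound 1 `CN1Cc2c(NC(=O)OCc3ccccc3)cccc2C(c2ccccc2)C1` gives about 15 mg/kg
- compound 2 `CC(C)NCC(=O)Nc1cccc2c1CN(C)CC2c1ccccc1` gives 14 mg/kg

Compound 2 stands level with compound 1 on these two numbers, and the gap between them lies within the scatter. The next compound, compound 3 `CC(C)NCCC(=O)Nc1cccc2c1CN(C)CC2c1ccccc1`, differs from compound 2 in one place: (isopropylamino)methyl in place of isopropylamino on a saturated chain carbon bound to a carbonyl carbon. Read one bond further out, (isopropylamino)methyl becomes 2-(isopropylamino)ethyl.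

Going by the values given here, only one measured step bears on this change: a 1.1-fold lower number from compound 1 to compound 2 (0.03 log units; within the scatter). In that step (isopropylamino)methyl took the place of benzyloxy on a carbonyl carbon, and the numbers stayed within the scatter. That step does not test the chain itself, so the evidence is indirect. On this evidence, no step beyond the scatter is expected in this assay, in either direction. The expected change is a 1.1-fold higher number from compound 2 to compound 3 (0.03 log units; within the scatter). For compound 3 the estimated value is 15 mg/kg, with an expected range from 7 mg/kg to 32 mg/kg.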

Compound 3, dose for half-maximal effect: 150 mg/kg
Estimate against measurement, compound 3: 10-fold (1.00 log units) below, and the stated range ends below it.
By their numbers in this assay, from the lowest: compounds 2 and 1 (each within the scatter of the next); then compound 3.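

In this assay, going by these compounds alone, the earlier compounds made this position look forgiving, since benzyloxy and (isopropylamino)methyl on a carbonyl carbon gave numbers within the scatter of each other. Lengthening the chain from (isopropylamino)methyl to 2-(isopropylamino)ethyl breaks that picture, with an 11-fold higher number from compound 2 to compound 3 (1.03 log units; beyond the scatter), so in this pair the chain length matters a great deal and the longer chain needs far more compound for the same effect. The longer chain also stands apart from the benzyloxy group, with a 10-fold higher number from compound 1 to compound 3 (1.00 log units; beyond the scatter), and nothing measured here accounts for the change.

The compounds shown leave open whether a still longer chain, such as 3-(isopropylamino)propyl, would raise the dose further, or whether the rise stops at 2-(isopropylamino)ethyl. They also leave open whether another amine, such as dimethylamino or piperidine, would stay level with compound 2 on the shorter chain, and whether it would suffer the same large rise on the longer one.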